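A pentyl chain replaces 2-methyl-3-nitrophenyl

The compounds below may be only part of what the source reports. "The series", "measured", "known", "first", "only" and "open" are said of these compounds alone.

In a functional assay on HepG2 cells (Homo sapiens) for antiproliferative activity, read by MTT assay (a higher number here means a weaker inhibitor, a lower number a stronger inhibitor), compound 1 (`CC1(C)CCc2cc(C(=O)/C=C/c3ccc(OCc4cn(-c5ccc(Br)cc5)nn4)cc3)c(O)cc2O1`) is reported as "not active" (no number reported), with no number. Among the compounds with values here, compound 2 (`Cc1c(-n2cc(COc3ccc(/C=C/C(=O)c4ccc5c(c4O)CCC(C)(C)O5)cc3)nn2)cccc1[N+](=O)[O-]`) gives 115000 nM, the only number available, so it cannot be ranked against a second measured value. Compound 3 (`CCCCCn1cc(COc2ccc(/C=C/C(=O)c3ccc4c(c3O)CCC(C)(C)O4)cc2)nn1`) keeps the shared core and differs from compound 2 in one place: pentyl in place of 2-methyl-3-nitrophenyl on an aromatic nitrogen. Within the data shown here, no measured step guides this change, so only a modest shift towards a lower number is expected in this assay. The estimated step is a 2.3-fold lower number from compound 2 to compound 3 (0.36 log units; beyond the scatter). For compound 3 the expected value is 50000 nM, with an estimated range of 12000 nM to 150000 nM.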

Compound 3, half-maximal inhibitory concentration: 9820 nM
Compound 3: middle estimate off by 5.1-fold (0.71 log units), on the high side, outside the stated range (below it).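

In this assay the substituent on this aromatic nitrogen clearly matters: pentyl in place of 2-methyl-3-nitrophenyl gives a 12-fold lower number from compound 2 to compound 3 (1.07 log units; beyond the scatter) and this step lies beyond the scatter. An aromatic ring is therefore not required at this place for a lower number, since pentyl has no ring and compound 3 still improves on compound 2. Nothing available accounts for the size of this step. As far as these compounds go, whether a longer chain such as octyl, a shorter chain such as propyl, or a cyclohexyl ring would lower the number further remains open.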